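This account rests on a few compounds, and the source may have more. Where it says the series, first, only, none or still open, it means among the compounds named here.

Compound 1 `COc1cc(-c2c(C)nn(-c3nc(-c4ccc(Cl)c(Cl)c4)c(SC(C)C)s3)c2C(=O)O)cc(C(F)(F)F)c1` is the more potent of the two compounds measured in a functional assay on BJAB cells (Homo sapiens) for antiproliferative activity, with a stated time of 4 days (on this read-out lower numbers stand for an effect already at smaller amounts and higher numbers for an effect only at larger amounts of compound), where compound 1 gives 1380 nM. Compound 2 `COc1ccccc1-c1c(C)nn(-c2nc(-c3ccc(Cl)c(Cl)c3)c(SC(C)C)s2)c1C(=O)O` gives 14700 nM, and the step of an 11-fold higher number from compound 1 to compound 2 (1.03 log units; beyond the scatter) shows how strongly the substitution pattern of this aryl ring sways the read-out. Compound 3 `Cc1nn(-c2nc(-c3ccc(Cl)c(Cl)c3)c(SC(C)C)s2)c(C(=O)O)c1-c1cc(C(F)(F)F)cc(C(F)(F)F)c1` differs from compound 1 by trifluoromethyl in place of methoxy on an aromatic carbon. For the measured compounds named here, no measured step tries this same exchange; the only step at hand, from compound 1 to compound 2, swaps the whole ring and therefore bears on it only loosely. The author expects a step of about a 1.1-fold higher number from compound 1 to compound 3 (0.04 log units; within the scatter), within the scatter, and estimates compound 3 at 1500 nM with a range of 400 nM to 6000 nM.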

Compound 3, half-maximal effective concentration: 1800 nM
The estimate for compound 3 lay 1.2-fold (0.08 log units) below the measured number, within the range that was stated.
By their numbers in this assay, from the lowest: compounds 1 and 3 (each within the scatter of the next); then compound 2.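

In this assay, the step of a 1.3-fold higher number from compound 1 to compound 3 (0.12 log units; within the scatter) shows that trifluoromethyl can stand in place of methoxy at this position without moving the read-out beyond the scatter. So the methoxy group is not needed here for activity at this level, as long as the other trifluoromethyl group stays on the ring. No measurement at hand gives a reason for this outcome. As far as these compounds go, whether an amine or a hydroxyl group would be tolerated at this position remains open, as does whether the exchange would give the same result without that other trifluoromethyl group.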